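This account rests on a few compounds, and the source may have more. Where it says the series, first, only, none or still open, it means among the compounds named here.

Compound 1 `Cc1cccc(-c2nc(CN3CCC(C(=O)NCCCN4C[C@H](C)C[C@H](C)C4)CC3)c(C)o2)c1` and compound 2 `Cc1ccc(-c2nc(CN3CCC(C(=O)NCCCN4C[C@H](C)C[C@H](C)C4)CC3)c(C)o2)cc1C` share one core and have both been tested in an ADME assay on microsomes from liver (Rattus norvegicus) for metabolic stability, read by LC-MS, using NADPH, at 37 degrees C; a lower number here means that the compound disappears faster, a higher number that the compound lasts longer. In this assay, compound 1 gives > 0.5 h, which is a limit of the assay and not a number. Compound 2 gives > 0.5 h, which is also a limit and not a number, so it has no exact place on the half-life scale. The picture so far is the limit of > 0.5 h in this assay, at which 2 of the 2 values shown sit. For the measured compounds named here, the only measured step is a step that the two limits leave unreadable from compound 1 to compound 2, which leaves no size to carry forward.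

Compound 3 `COc1ccc(-c2nc(CN3CCC(C(=O)NCCCN4C[C@H](C)C[C@H](C)C4)CC3)c(C)o2)cc1OC` has not yet been measured. Its change from compound 2 is 3,4-dimethoxyphenyl in place of 3,4-dimethylphenyl on an aromatic carbon of a five-membered aromatic ring with 1 nitrogen and 1 oxygen. Going by the values given here, no measured step covers this swap, so the data favour no direction, and no change beyond the scatter is expected. The expected step is a number no higher from compound 2 to compound 3 (the limit leaves the size open). The estimated half-life of compound 3 is 0.5 h, with an expected range from 0.2 h to 1 h.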

Compound 3, half-life: > 0.5 h
Compound 3: only a limit was reported; the forecaster's own chance of this, stated with the estimate: 60%; the middle value sits exactly at the limit.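

In this assay compound 3 gives > 0.5 h, which is a limit and not a number. For the compounds shown here, no step among compound 1, compound 2 and compound 3 can be read. The compounds shown leave open how long each one actually lasts, and whether 3-methylphenyl, 3,4-dimethylphenyl and 3,4-dimethoxyphenyl differ at all in half-life: the limit of > 0.5 h in this assay, at which 3 of the 3 values shown sit.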